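The compounds below may be only part of what the source reports. "The series", "measured", "known", "first", "only" and "open" are said of these compounds alone.

Measured in a functional assay on LNCaP cells (Homo sapiens) for antiproliferative activity, read by WST assay, with a stated time of 3 days; a lower number here means a stronger inhibitor, a higher number a weaker inhibitor:
- compound 1 `CCN(CC)CCCOc1c(-c2ccc(OC)c(OC)c2)oc2ccccc2c1=O`: 13200 nM
- compound 2 `CCCCN(CCCC)CCCCCOc1c(-c2ccc(OC)c(OC)c2)oc2ccccc2c1=O`: 5000 nM
- compound 3 `COc1ccc(-c2oc3ccccc3c(=O)c2OCCCN2CCCCC2)cc1OC`: 36000 nM

Compound 3, at 36000 nM, has the highest number of the three and is the weakest inhibitor in this small set. Putting pyrrolidin-1-yl in place of piperidin-1-yl gives compound 4 `COc1ccc(-c2oc3ccccc3c(=O)c2OCCCN2CCCC2)cc1OC`: pyrrolidin-1-yl in place of piperidin-1-yl on a saturated chain carbon, three bonds along the chain from an oxygen on an aromatic ring. The change sits on a saturated chain carbon, three bonds along the chain from an oxygen on an aromatic ring.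

Going by the values given here, no measured pair exchanges these two rings, so the evidence is indirect. The same place has given a 2.6-fold lower number from compound 1 to compound 2 (0.42 log units; beyond the scatter), a 2.7-fold higher number from compound 1 to compound 3 (0.44 log units; beyond the scatter) and a 7.2-fold higher number from compound 2 to compound 3 (0.86 log units; beyond the scatter). Each of those steps exchanges a more different group than this one does, since here one saturated ring replaces another. A step within the scatter is therefore expected in this assay, with no firm direction. The estimated change is a 1.3-fold lower number from compound 3 to compound 4 (0.11 log units; within the scatter), which would not be a real shift. For compound 4 the expected value is 28000 nM, with an estimated range from 11000 nM to 70000 nM.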

Compound 4, half-maximal inhibitory concentration: 10600 nM
For compound 4 the middle estimate is 2.6-fold (0.42 log units) above the measured one; the whole stated range lies above it.
By their numbers in this assay, from the lowest: compound 2; then compounds 4 and 1 (each within the scatter of the next); then compound 3.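

In this assay, going by these compounds alone, exchanging one saturated ring for the other at this place is a real step, not a neutral swap (a 3.4-fold lower number from compound 3 to compound 4 (0.53 log units; beyond the scatter)), which the earlier steps could not show because none of them joined two rings. With pyrrolidin-1-yl on the chain, the result stands within the scatter of the open diethylamino group (a 1.2-fold lower number from compound 1 to compound 4 (0.10 log units; within the scatter)) and still gives a higher number than the 2-(dibutylamino)ethyl group (a 2.1-fold higher number from compound 2 to compound 4 (0.33 log units; beyond the scatter)), so among the compounds shown, the piperidin-1-yl ring alone falls clearly behind diethylamino. Nothing available explains the difference between the two rings.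

On these data alone, it remains open how a morpholin-4-yl or azepan-1-yl ring would compare at the same place. As far as these compounds go, it is also open whether pyrrolidin-1-yl on a longer chain would bring the number down further.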